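Shortening the oxygen-bound chain: compound 2 to compound 3

The compounds below may be only part of what the source reports. "The series", "measured", "known", "first", "only" and "open" are said of these compounds alone.

Compound 1 `CCCCCCOC(=O)c1cccc(-c2cc(C(=O)Nc3ccncc3)ccc2CN)c1`: 22 nM in an assay on isolated protein for inhibition of Rho-associated protein kinase 2 (Homo sapiens), read by radiometric assay; a higher number here means a weaker inhibitor, a lower number a stronger inhibitor
Compound 2 `CCCOC(=O)c1cccc(-c2cc(C(=O)Nc3ccncc3)ccc2CN)c1`: 1.4 nM

Among the measured compounds shown here, compound 2 stands lowest of the two numbers measured so far; the single measured step, a 16-fold lower number from compound 1 to compound 2 (1.20 log units; beyond the scatter), is large and runs toward lower numbers. Compound 3 `COC(=O)c1cccc(-c2cc(C(=O)Nc3ccncc3)ccc2CN)c1` carries hydrogen in place of ethyl on a saturated chain carbon bound to an oxygen next to a carbonyl group, the same chain cut shorter again at the same place. For the measured compounds named here, only that one step bears on it, and it points one way, so for compound 3 a further shift toward a lower number, or none beyond the scatter, is expected, a 1.4-fold lower number from compound 2 to compound 3 (0.15 log units; within the scatter). Compound 3 is therefore estimated at 1 nM, with a range from 0.3 nM to 4 nM.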

Compound 3, half-maximal inhibitory concentration: 2.9 nM
For compound 3 the middle estimate is 2.9-fold (0.46 log units) below the measured one, within the range that was stated.
By their numbers in this assay, from the lowest: compound 2; then compound 3; then compound 1.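

Shortening the oxygen-bound chain stops paying at propyl: in this assay, going from propyl to methyl reverses the earlier direction (a 2.1-fold higher number from compound 2 to compound 3 (0.32 log units; beyond the scatter)). Among these three compounds, the number therefore does not follow chain length in one direction, and compound 2 has the lowest value. The methyl chain still sits well under the longest chain (a 7.6-fold lower number from compound 1 to compound 3 (0.88 log units; beyond the scatter)). No measured evidence accounts for this reversal.

Still open, as far as these compounds go, is where an ethyl chain would fall between propyl and methyl in this assay. Also open, from the compounds shown here alone, is how a carboxylic acid or a primary amide in place of propoxycarbonyl would read.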